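Swapping Fluorine for Methoxy: An Estimate Without a Baseline

The compounds below may be only part of what the source reports. "The series", "measured", "known", "first", "only" and "open" are said of these compounds alone.

Compound 3 `O=C(/C=C/c1ccc(F)cc1)c1ccc(OCc2ccccc2)cc1` was entered in a functional assay on HCT-116 cells (Homo sapiens) for antiproliferative activity, read by sulforhodamine B assay, with a stated time of 3 days, tested at 25 uM (on this read-out lower numbers stand for a weaker effect and higher numbers for a stronger effect at the one concentration tested), yet for compound 3 the outcome is "not determined" (no result reported), so no number shows where it stands. Compound 4 `COc1cccc(/C=C/C(=O)c2ccc(OCc3ccccc3)cc2)c1` differs from it by 3-methoxyphenyl in place of 4-fluorophenyl on a double-bonded chain carbon bound to a double-bonded chain carbon. Among the measured compounds shown here, the one measured step concerns a different group on the same ring: compound 1 `O=C(/C=C/c1ccccc1Cl)c1ccc(OCc2ccccc2)cc1` gives 54.5% and compound 2 `O=C(/C=C/c1ccccc1)c1ccc(OCc2ccccc2)cc1` gives 24.3% in this assay, a change of a number 30.2 percentage points lower from compound 1 to compound 2 (beyond the scatter). That step shows a single substituent on this ring can matter greatly, but it involves neither methoxy nor fluorine, so it sets no direction for the present change. With compound 3 lacking a number, no step size can be stated. Compound 4 is expected to give roughly 35%, estimated between 10% and 60%.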

Compound 4, a percentage reported as inhibition, at one concentration (the size of the read-out at that concentration, not a potency): 35.4%
Compound 4: middle estimate off by 0.4 percentage points, on the low side; low and high end bracket the measured number.
By their numbers in this assay, from the lowest: compound 2; then compound 4; then compound 1.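

Among the compounds shown here, with a number 11.1 percentage points higher from compound 2 to compound 4 (beyond the scatter) in this assay the methoxy group lifts the read-out over the unsubstituted ring, so chloro is not the only group here that raises it. Yet 3-methoxyphenyl falls short of 2-chlorophenyl, with a number 19.1 percentage points lower from compound 1 to compound 4 (beyond the scatter) as the gap at this place. Nothing measured here tells why these groups differ.

Compound 3 has no number, so the steps from it to the other compounds cannot be read, and 4-fluorophenyl stays unplaced. From the compounds shown here alone, how an amine or a carboxylic acid on this ring would fare also remains open.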